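A few compounds are considered here, and "the series" means these few. Any claim that something is new, unique, unknown or untested is made for them only; others in the source may bear on it.

Measured in an ADME assay on LLC-MK2 cells (Macaca mulatta) for cytotoxicity, read by spectrophotometry and crystal violet staining, with a stated time of 4 days; on this read-out lower numbers stand for higher toxicity in this test and higher numbers for lower toxicity in this test:
Compound 1 `CC(C)n1ncc2c(C(=O)N3CCc4cccnc43)cc(-c3cccs3)nc21`: 50000 nM
Compound 2 `CC(C)n1ncc2c(C(=O)Nc3ccncn3)cc(-c3ccsc3)nc21`: > 200000 nM

Within the data shown here, compound 1 holds the only actual number in this small set, at 50000 nM. Compound 2 gives > 200000 nM, which is a limit of the assay and not a number. Compound 3 `CC(C)n1ncc2c(C(=O)Nc3ccc(F)cn3)cc(-c3cccs3)nc21` has not yet been measured. It keeps the core of compound 1 and differs only in the group on a carbonyl carbon: a group of 8 heavy atoms (5 carbon, 2 nitrogen, 1 fluorine; one six-membered aromatic ring with 1 hetero atom) in place of a group of 9 heavy atoms (7 carbon, 2 nitrogen; one five-membered non-aromatic ring with 1 hetero atom, one six-membered aromatic ring with 1 hetero atom), on a carbonyl carbon. Among the measured compounds shown here, no measured step isolates this change. In this assay, a modest step towards higher numbers, meaning lower toxicity, is expected, and the estimated step is a 2.2-fold higher number from compound 1 to compound 3 (0.34 log units; beyond the scatter). For the measured compounds named here, this expectation leans on compound 2 with its limit of > 200000 nM, the only other reading available. For compound 3 the estimate is 110000 nM, with an expected range of 30000 nM to 300000 nM.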

Compound 3, half-maximal cytotoxic concentration: > 200000 nM
Compound 3: a limit, no number (the forecaster's own chance of this, stated with the estimate: 30%); middle value at least 1.8-fold (0.25 log units) from the limit.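

In this assay, among these compounds, the change on the carbonyl carbon gives the first step that can be read at this place: an at least 4.0-fold higher number from compound 1 to compound 3 (0.60 log units; beyond the scatter). Compound 3 gives > 200000 nM, which is a limit of the assay and not a number. The step therefore fixes only a direction and a lower bound, showing that the open (5-fluoropyridin-2-yl)amino group, with its amide hydrogen, reads on the less toxic side of the ring-closed amide of compound 1, while its full size stays out of reach: the limit of > 200000 nM in this assay, at which 2 of the 3 values shown sit.

The compounds shown leave open whether the fluorine plays any part in this step, which a pyridin-2-ylamino group without it, or one carrying chlorine instead, would help to settle. They also leave open whether an amide hydrogen alone goes with the higher reading, as a simple methylamino or a morpholine on the carbonyl carbon could test.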